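Swapping the halogenated ring on an imine-linked scaffold

This account rests on a few compounds, and the source may have more. Where it says the series, first, only, none or still open, it means among the compounds named here.

Of the compounds shown here, two have been tested in an ADME assay on cells (Rhabdomyosarcoma cell, Homo sapiens) for cytotoxicity, read by MTT assay, with a stated time of 72 h; on this read-out lower numbers stand for higher toxicity in this test and higher numbers for lower toxicity in this test. Compound 1 `C(=C/c1ccccc1)\C=N\c1sc2c(c1-c1nc3ccccc3s1)CCC2` gives 122 ug/mL in this assay. Compound 2 `Fc1ccc(/C=N/c2sc3c(c2-c2nc4ccccc4s2)CCCC3)cc1` gives 230 ug/mL in this assay, the higher of the two numbers, though the gap to compound 1 lies within the usual scatter. Compound 3 `Clc1ccccc1/C=N/c1sc2c(c1-c1nc3ccccc3s1)CCCC2` is obtained from compound 2 by the change (2-chlorophenyl in place of 4-fluorophenyl on a carbon with a double bond to nitrogen). Within the data shown here, with no earlier step of this kind to lean on, the expected step of a 1.2-fold lower number from compound 2 to compound 3 (0.06 log units; within the scatter) is small, in neither direction beyond the scatter. Compound 3 is thus expected to give about 200 ug/mL in this assay, in the range 100 ug/mL to 400 ug/mL.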

Compound 3, half-maximal cytotoxic concentration: 332 ug/mL
Compound 3: the middle estimate sits 1.7-fold (0.22 log units) below what was measured, and the stated range covers the measured number.
By their numbers in this assay, from the lowest: compounds 1, 2 and 3 (each within the scatter of the next, the first and the last beyond it).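

Putting 2-chlorophenyl in place of 4-fluorophenyl on the carbon with a double bond to nitrogen gives a 1.4-fold higher number from compound 2 to compound 3 (0.16 log units; within the scatter), so this one swap of halogenated rings does not move the number beyond the scatter. Because the halogen and its ring position both differ in this step, their separate contributions cannot be told apart. No measured evidence bears on the cause of this result.

Still open, as far as these compounds go, is whether 4-chlorophenyl, or a phenyl ring carrying an amine or a carboxylic acid, would give a step beyond the scatter at this place.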